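Amine exchange on the acrylamide chain of the shared core

The source may hold more compounds than are shown below. What is called first, only, known or untested is meant among the compounds shown, and "the series" means these compounds.

Compound 1 `C=CC(=O)Nc1cc2c(N3CCc4ccccc43)ncnc2cc1OC` gives 5580 nM in a functional assay on A549 cells (Homo sapiens) for antiproliferative activity, read by MTT assay, with a stated time of 72 h; on this read-out higher numbers stand for weaker inhibition and lower numbers for stronger inhibition. Compound 2 `COc1cc2ncnc(N3CCc4ccccc43)c2cc1NC(=O)/C=C/CN(C)C` carries 3-(dimethylamino)prop-1-en-1-yl in place of vinyl on the carbonyl carbon and gives 2040 nM in this assay; the step is a 2.7-fold lower number from compound 1 to compound 2 (0.44 log units; beyond the scatter). Among the measured compounds shown here, compound 2 therefore stands at the lowest of the two numbers measured so far, with compound 1 as its only neighbour. Compound 3 `COc1cc2ncnc(N3CCc4ccccc43)c2cc1NC(=O)/C=C/CN1CCCC1` differs from compound 2 in one place, on a saturated chain carbon bound to a double-bonded chain carbon: pyrrolidin-1-yl in place of dimethylamino on a saturated chain carbon bound to a double-bonded chain carbon. For the measured compounds named here, the single measured step bears on this only at a distance, since it concerns the introduction of the whole amine-bearing chain rather than the exchange of one amine for another; the chain itself is kept in compound 3. Going by the values given here, no measured pair compares dimethylamino with pyrrolidin-1-yl. The expected step in this assay from compound 2 to compound 3 is therefore a 1.1-fold lower number from compound 2 to compound 3 (0.05 log units; within the scatter), within the scatter. For compound 3 the expected value is 1800 nM with a range from 900 nM to 3600 nM.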

Compound 3, half-maximal inhibitory concentration: 1210 nM
The estimate for compound 3 lay 1.5-fold (0.17 log units) above the measured number, within the range that was stated.
By their numbers in this assay, from the lowest: compounds 3 and 2 (each within the scatter of the next); then compound 1.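

In this assay, the exchange at the saturated chain carbon bound to a double-bonded chain carbon gives a 1.7-fold lower number from compound 2 to compound 3 (0.23 log units; within the scatter), so closing the amine into the pyrrolidin-1-yl ring, with 5 heavy atoms in place of 3, leaves the result within the scatter of the dimethylamino compound. The separation from the vinyl compound holds with the new amine, at a 4.6-fold lower number from compound 1 to compound 3 (0.66 log units; beyond the scatter), alongside the earlier 2.7-fold lower number from compound 1 to compound 2 (0.44 log units; beyond the scatter), so both amine-bearing chains shown give numbers beyond the scatter of compound 1, and neither of the two amines can be ranked over the other in these data. No measurement at hand bears on the cause of these steps.

From the compounds shown here alone, it remains open whether a six-membered amine such as piperidin-1-yl or morpholin-4-yl, or an open-chain diethylamino group, would stay with compound 2 and compound 3 or move away from them. Going by these compounds, it is also open whether the amine nitrogen matters at all, since a chain ending in a methoxy or hydroxyl group in the same place would be needed to separate the effect of the nitrogen from that of the longer chain.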